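The source may hold more compounds than are shown below. What is called first, only, known or untested is meant among the compounds shown, and "the series" means these compounds.

Measured compounds:
compound 1 `CO[C@H]1C(=O)N2C(C(=O)C(C)(C)C)=C(C)[C@@H](Sc3nnnn3C)S(=O)(=O)C12` — 18 h
compound 2 `CO[C@H]1C(=O)N2C(C(=O)c3ccccc3)=C(C)[C@@H](Sc3nnnn3C)S(=O)(=O)C12` — 200 h
compound 3 `CO[C@H]1C(=O)N2C(C(=O)C(C)(C)C)=C(C)[C@@H](OC(=O)c3ccc4ccccc4c3)S(=O)(=O)C12` — 33 h

In a physicochemical assay, at pH 7.4 (a lower number here means that the compound disappears faster, a higher number that the compound lasts longer), compound 1 gives the lowest number of the three; compound 3 sits within the scatter of it, and compound 2 lies well beyond it, as shown by an 11-fold higher number from compound 1 to compound 2 (1.05 log units; beyond the scatter). Compound 4 `CO[C@H]1C(=O)N2C(C(=O)C(C)(C)C)=C(C)[C@@H](S(=O)(=O)c3ccccc3)S(=O)(=O)C12` differs from compound 1 only in phenylsulfonyl in place of (1-methyl-1H-tetrazol-5-yl)sulfanyl on a saturated ring carbon. Among the measured compounds shown here, no measured step changes the group at this saturated ring carbon; the large step from compound 1 to compound 2 concerns the carbonyl substituent, a different place. Compound 3 carries another group at the same ring carbon, and its half-life and that of compound 1 fall within the scatter. Compound 4 is therefore expected to stay close to compound 1, with a 1.5-fold lower number from compound 1 to compound 4 (0.18 log units; within the scatter). The estimate for compound 4 is 12 h, with a range from 4 h to 40 h.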

Compound 4, half-life: 10 h
Compound 4: middle estimate off by 1.2-fold (0.08 log units), on the high side, and the stated range covers the measured number.
By their numbers in this assay, from the lowest: compounds 4, 1 and 3 (each within the scatter of the next, the first and the last beyond it); then compound 2.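

Among the compounds shown here, measured in this assay, the swap gives a 1.8-fold lower number from compound 1 to compound 4 (0.26 log units; within the scatter) and is the first change at this saturated ring carbon that can be read on its own. Phenylsulfonyl and (1-methyl-1H-tetrazol-5-yl)sulfanyl, two groups with different aromatic rings, therefore cannot be told apart at this place on the shared core. Nothing at hand explains this result.

From the compounds shown here alone, whether the same holds alongside the phenyl carbonyl of compound 2 remains open. So does the effect of an amine or a carboxylic acid at this ring carbon.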